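Bicyclic amide in place of cyclohexyl on the shared core

The source may report more compounds than this note shows. Statements on the series, on what has been measured and on what is new or still open speak of the compounds shown alone.

Compound 1 `O=C(C1CCCCC1)N1CC(c2nc(-c3cccc(F)c3)no2)C1` gives 1000 nM in an assay on HEK293 cells for positive allosteric modulation of metabotropic glutamate receptor 5 (Homo sapiens), read by FLIPR (on this read-out lower numbers stand for an effect already at smaller amounts and higher numbers for an effect only at larger amounts of compound), and stands second highest of the three numbers shown. Its nearest neighbour is compound 3 `O=C(C1CCC2(CCC2)CC1)N1CC(c2nc(-c3cccc(Cl)c3)no2)C1`, which gives 1100 nM; the two values lie within the scatter of each other. Compound 2 `O=C(C1CCC(C(F)(F)F)CC1)N1CC(c2nc(-c3cccc(F)c3)no2)C1` gives 680 nM, and the step of a 1.5-fold lower number from compound 1 to compound 2 (0.17 log units; within the scatter) is within the scatter as well. Compound 3 differs from compound 1 in two places, so its value can only be set beside that of compound 1 without reading a step from it.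

Compound 4 `O=C([C@@H]1CC2CCC1C2)N1CC(c2nc(-c3cccc(F)c3)no2)C1` differs from compound 1 in one place: a group of 7 heavy atoms (7 carbon; 2 five-membered non-aromatic rings of carbon only) in place of a group of 6 heavy atoms (6 carbon; one six-membered non-aromatic ring of carbon only), on a carbonyl carbon. For the measured compounds named here, the one measured step on the same amide-bound ring, a 1.5-fold lower number from compound 1 to compound 2 (0.17 log units; within the scatter), is within the scatter, and no measured compound carries a bicyclic group there. A step of no more than the scatter is therefore expected, in either direction, and compound 4 is estimated to give 900 nM, between 400 nM and 2500 nM, which means an expected step of a 1.1-fold lower number from compound 1 to compound 4 (0.05 log units; within the scatter).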

Compound 4, half-maximal effective concentration: 100 nM
Beside the measured number, compound 4's estimate is 9.0-fold (0.95 log units) above it; measured number outside the range, below it.
By their numbers in this assay, from the lowest: compound 4; then compounds 2, 1 and 3 (each within the scatter of the next).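

In this assay, the group on the carbonyl carbon now proves able to move the number beyond the scatter: replacing cyclohexyl with the group of 7 heavy atoms, with its 2 five-membered non-aromatic rings of carbon only, gives a 10-fold lower number from compound 1 to compound 4 (1.00 log units; beyond the scatter). The earlier change at this place, trifluoromethyl on the saturated ring, gave only a 1.5-fold lower number from compound 1 to compound 2 (0.17 log units; within the scatter), so that step did not show how far this position can respond. Both the leaving and the entering group are carbon only, with no hydrogen-bond donors or acceptors and no net charge, and no evidence is available on what lies behind the shift.

The compounds shown leave open how much the defined stereocentre of compound 4 contributes. They also leave open whether a hydroxyl group or an amine on the group of 7 heavy atoms would keep the lower number.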